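A few compounds are considered here, and "the series" means these few. Any claim that something is new, unique, unknown or untested is made for them only; others in the source may bear on it.

Measured so far in a functional assay on the whole organism (Tail, strain ICR) with Mus musculus as the target, in the tail flick test, with a stated time of 60 min, at a dose of 25 umol/kg by the oral route; on this read-out lower numbers stand for a weaker effect and higher numbers for a stronger effect at the one dose given:
compound 1, `NC(=O)C[C@H](NC(=O)CN(c1nc(Cl)nc2[nH]cnc12)C1CC1)C(=O)O`, gives 43.1%
compound 2, `NCCCC[C@H](NC(=O)CN(c1nc(Cl)nc2[nH]cnc12)C1CC1)C(=O)O`, gives 53.8%

For the measured compounds named here, compound 2 holds the higher of the two numbers in this assay; the single measured step, a number 10.7 percentage points higher from compound 1 to compound 2 (beyond the scatter), separates it from compound 1, its only neighbour.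

Compound 3, `CSCC[C@H](NC(=O)CN(c1nc(Cl)nc2[nH]cnc12)C1CC1)C(=O)O`, differs from compound 2 by methylsulfanyl in place of 2-aminoethyl on a saturated chain carbon, three bonds along the chain from an amide-type nitrogen and a carbonyl carbon. Going by the values given here, no measured step bears directly on this change: the one step seen so far swaps carbamoyl for 3-aminopropyl, a different group, and it was modest. The change to compound 3 removes the hydrogen-bond donor of the 2-aminoethyl group while keeping one acceptor. With nothing measured to anchor it, the expectation for compound 3 in this assay is a modest downward step, a number 8.8 percentage points lower from compound 2 to compound 3 (within the scatter), with a result inside the scatter also plausible. Compound 3 is therefore estimated at 45%, within a range from 27% to 63%.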

Compound 3, a percentage reported as activity, at one dose (the size of the read-out at that dose, not a potency): 22.8%
The estimate for compound 3 lay 22.2 percentage points above the measured number; the whole stated range lies above it.
By their numbers in this assay, from the lowest: compound 3; then compound 1; then compound 2.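

In this assay this position proves more sensitive than the earlier pair alone could show: methylsulfanyl in place of 2-aminoethyl gives a number 31 percentage points lower from compound 2 to compound 3 (beyond the scatter), a large step set against the modest one that was the only measure before. The comparison with the carbamoyl side chain points the same way, with (methylsulfanyl)methyl in place of carbamoyl giving a number 20.3 percentage points lower from compound 1 to compound 3 (beyond the scatter), so among these three side chains the one ending in methylsulfanyl sits lowest, and neither other compound goes against that. Nothing measured here accounts for the drop.

Open, going by these compounds, is whether the fall follows the sulfur atom or the absence of the terminal amine; a plain butyl chain and a side chain ending in a carboxylic acid would help separate the two. On these data alone, the reading also rests on one dose and one time point, so whether this order holds elsewhere on the dose range remains unknown.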